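Swapping cyclohexylmethyl for phenyl on a weak cytotoxic amide

This account rests on a few compounds, and the source may have more. Where it says the series, first, only, none or still open, it means among the compounds named here.

Measured so far in an ADME assay on HCT-116 cells (Homo sapiens) for cytotoxicity, read by MTT assay, with a stated time of 72 h; a lower number here means a stronger inhibitor, a higher number a weaker inhibitor:
- compound 1 `O=C(NCC1CCCCC1)c1cccc(/C=C2\CC(=O)N(c3ccccc3)C2=O)c1` gives > 100000 nM, which is a limit of the assay rather than a number.
- compound 2 `CCc1cccc(NC(=O)c2cccc(/C=C3\CC(=O)N(Cc4ccccc4)C3=O)c2)c1` gives 80600 nM.
- compound 3 `CCCCCN1C(=O)C/C(=C\c2cccc(C(=O)NCCCC)c2)C1=O` gives > 100000 nM, again a limit of the assay and not a number.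

Compound 1 therefore stands at the upper boundary of what this assay can report, and it shares that position with compound 3, as the limit of > 100000 nM in this assay, at which 2 of the 3 values shown sit, makes plain. Compound 2 is the only one of the three with an actual number, and that number sits close to the same boundary.

The step to compound 4 `O=C(Nc1ccccc1)c1cccc(/C=C2\CC(=O)N(c3ccccc3)C2=O)c1` changes one group: phenyl in place of cyclohexylmethyl on an amide-type nitrogen. Among the measured compounds no single-point comparison exists that would show what such a change does in this assay, so the expectation rests on the general picture, in which every measured value lies at or near the limit. The expected step that the limit leaves unreadable from compound 1 to compound 4 is none beyond the scatter.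

For compound 4 the estimate in this assay is 120000 nM, within a range from 50000 nM to 300000 nM.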

Compound 4, half-maximal inhibitory concentration: > 100000 nM
Compound 4: a limit, no number; the forecaster's own chance of this, stated with the estimate: 70%; the middle value lies beyond the limit too.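

Compound 4, like compound 1, returns a limit of the assay rather than a number, so the swap of cyclohexylmethyl for phenyl gives no readable step. The compounds shown leave open whether this swap changes cytotoxicity at all, and the values offer little to compare: the limit of > 100000 nM in this assay, at which 3 of the 4 values shown sit.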